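Butyl gives way to 4-methylpiperazin-1-yl

The source may hold more compounds than are shown below. What is called first, only, known or untested is meant among the compounds shown, and "the series" means these compounds.

In a functional assay on HepG2 cells (Homo sapiens) for inhibition, read by MTT assay, with a stated time of 72 h (a higher number here means a weaker inhibitor, a lower number a stronger inhibitor), compound 1 `Cc1ccc(NC(=O)C2CCN(C/C=C/c3ccccc3)CC2)cc1` gives 33900 nM and compound 2 `CCCCc1ccc(NC(=O)C2CCN(C/C=C/c3ccccc3)CC2)cc1` gives 4320 nM as the lower of the two numbers. Compound 3 `CN1CCN(c2ccc(NC(=O)C3CCN(C/C=C/c4ccccc4)CC3)cc2)CC1` carries 4-methylpiperazin-1-yl in place of butyl on an aromatic carbon. Going by the values given here, the one measured step (a 7.8-fold lower number from compound 1 to compound 2 (0.89 log units; beyond the scatter)) built up the chain that now leaves, so part of that drop is expected to be given back, although a ring is not simply a chain and one step is thin evidence. The expected change (a 2.5-fold higher number from compound 2 to compound 3 (0.41 log units; beyond the scatter)) is a move to a higher number. Compound 3 is estimated at 11000 nM (range 3000 nM to 35000 nM).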

Compound 3, half-maximal inhibitory concentration: 35200 nM
Estimate against measurement, compound 3: 3.2-fold (0.51 log units) below, outside the stated range (above it).
By their numbers in this assay, from the lowest: compound 2; then compounds 1 and 3 (each within the scatter of the next).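

Swapping butyl for 4-methylpiperazin-1-yl gives an 8.1-fold higher number from compound 2 to compound 3 (0.91 log units; beyond the scatter) in this assay and shows that adding heavy atoms at this position does not by itself lower the number. Set against the methyl group, the same ring gives a 1.0-fold higher number from compound 1 to compound 3 (0.02 log units; within the scatter) and so leaves compound 3 level with compound 1 within the scatter. Nothing available explains this difference between the two groups. The compounds shown leave open whether the ring or its nitrogens set the number. Cyclohexyl, a ring of carbon only, or a longer chain such as hexyl would speak to that.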